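From 4-nitrophenyl to heptyl on the shared core

The compounds below may be only part of what the source reports. "The series", "measured", "known", "first", "only" and "open" are said of these compounds alone.

In a functional assay on MCF7 cells (Homo sapiens) for inhibition, read by MTT assay, with a stated time of 48 h (a higher number here means a weaker inhibitor, a lower number a stronger inhibitor), compound 1 `CN(C)c1ccc(C(c2c[nH]c3ccc(Br)cc23)c2c[nH]c3ccc(Br)cc23)cc1` gives 24900 nM, while compound 2 `O=[N+]([O-])c1ccc(C(c2c[nH]c3ccc(Br)cc23)c2c[nH]c3ccc(Br)cc23)cc1` gives 3100 nM, the lower of the two numbers. Compound 3 `CCCCCCCC(c1c[nH]c2ccc(Br)cc12)c1c[nH]c2ccc(Br)cc12` carries heptyl in place of 4-nitrophenyl on a saturated chain carbon bound to two aromatic carbons. Going by the values given here, the only measured step, an 8.0-fold lower number from compound 1 to compound 2 (0.90 log units; beyond the scatter), put nitro in place of dimethylamino on an aromatic carbon. It leaves the 4-nitrophenyl replacement untested and offers only a rough size. A modest rise is expected in this assay, estimated as a 2.6-fold higher number from compound 2 to compound 3 (0.41 log units; beyond the scatter). The expected value for compound 3 is 8000 nM, within an estimated range of 2500 nM to 25000 nM.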

Compound 3, half-maximal inhibitory concentration: 5500 nM
The estimate for compound 3 lay 1.5-fold (0.16 log units) above the measured number; the measured number falls inside the stated range.
By their numbers in this assay, from the lowest: compounds 2 and 3 (each within the scatter of the next); then compound 1.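

In this assay heptyl in place of 4-nitrophenyl gave a 1.8-fold higher number from compound 2 to compound 3 (0.25 log units; within the scatter) and so, at this saturated chain carbon bound to two aromatic carbons, a group with no ring cannot be told apart from 4-nitrophenyl. Heptyl in place of 4-(dimethylamino)phenyl gave a 4.5-fold lower number from compound 1 to compound 3 (0.66 log units; beyond the scatter) and shows that an aromatic ring is not needed here for the lower numbers. Nothing at hand bears on the reason for either step. Open, on these data alone, is whether a shorter or longer chain would give similar numbers. Also open, as far as these compounds go, is how a chain ending in an amine or a carboxylic acid, or a cyclohexyl ring, would compare.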